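A few compounds are considered here, and "the series" means these few. Any claim that something is new, unique, unknown or untested is made for them only; others in the source may bear on it.

In a functional assay for inhibition, read by fluorescence and spectrophotometry, with a stated time of 30 h (on this read-out higher numbers stand for weaker inhibition and lower numbers for stronger inhibition), three compounds have been measured so far. Compound 1 `COc1ccc(-c2cc(=O)c3ccc(O)cc3o2)cc1OC` gives 47400 nM, compound 2 `COc1cc(-c2cc(=O)c3ccc(O)cc3o2)cc(OC)c1OC` gives 51400 nM, and compound 3 `COc1ccc(-c2cc(=O)c3ccc(OCCCN4CCC(C)CC4)cc3o2)cc1OC` gives 47700 nM. All three numbers lie within the scatter of one another, so compound 3 stands level with the other two and they cannot be ranked.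

Compound 4 `COc1cc(-c2cc(=O)c3ccc(OCCCN4CCC(C)CC4)cc3o2)cc(OC)c1OC` is compound 3 with a single change: methoxy in place of hydrogen on an aromatic carbon. Here methoxy takes the place of hydrogen on an aromatic carbon. The same swap has been measured once before, as a 1.1-fold higher number from compound 1 to compound 2 (0.04 log units; within the scatter). The other measured step, which attaches the 3-(4-methylpiperidin-1-yl)propyl group, is a 1.0-fold higher number from compound 1 to compound 3 (0.00 log units; within the scatter). Neither step leaves the scatter, although a single earlier example is thin evidence. No step beyond the scatter is therefore expected in this assay, in either direction. The estimated step is a 1.1-fold higher number from compound 3 to compound 4 (0.03 log units; within the scatter). For compound 4 the expected value is 51000 nM, with an estimated range of 30000 nM to 85000 nM.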

Compound 4, half-maximal inhibitory concentration: 41800 nM
Compound 4: middle estimate off by 1.2-fold (0.09 log units), on the high side, and the stated range covers the measured number.
By their numbers in this assay, from the lowest: compounds 4, 1, 3 and 2 (each within the scatter of the next).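

In this assay, the methoxy swap now has a second example, on a core carrying the 3-(4-methylpiperidin-1-yl)propyl group, with a 1.1-fold lower number from compound 3 to compound 4 (0.06 log units; within the scatter), and it again stays within the scatter: the same change on two cores in this assay, a 1.1-fold higher number (0.04 log units; within the scatter) from compound 1 to compound 2 and a 1.1-fold lower number (0.06 log units; within the scatter) from compound 3 to compound 4, 1.2-fold (0.09 log units) apart, within the scatter of two such steps. Attaching the 3-(4-methylpiperidin-1-yl)propyl group also has a second example, on the core of compound 2, with a 1.2-fold lower number from compound 2 to compound 4 (0.09 log units; within the scatter), and the two readings agree: the same change on two cores in this assay, a 1.0-fold higher number (0.00 log units; within the scatter) from compound 1 to compound 3 and a 1.2-fold lower number (0.09 log units; within the scatter) from compound 2 to compound 4, 1.2-fold (0.09 log units) apart, within the scatter of two such steps. So each change leaves the number level on both cores shown, whether or not the other change is present.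

Still open, on these data alone, is whether any group at these two places can move the number at all. A chlorine or hydroxyl in place of this methoxy, or a longer chain or a primary amine in place of the 3-(4-methylpiperidin-1-yl)propyl group, would test that.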